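Extending the chain beyond compound 2

The source may hold more compounds than are shown below. What is called first, only, known or untested is meant among the compounds shown, and "the series" means these compounds.

In a functional assay on NCI-H630 cells (Homo sapiens) for cytotoxicity, read by sulforhodamine B assay, with a stated time of 5 days (on this read-out lower numbers stand for stronger inhibition and higher numbers for weaker inhibition), compound 1 `O=C(CCCCCCCc1ccccc1)N[C@H]1CCOC1=O` gives > 100000 nM as its result, which is a limit of the assay and not a number. In this assay compound 2 `O=C(CCCCCCCCc1ccccc1)N[C@H]1CCOC1=O` gives > 100000 nM as its result, again only a limit. Compound 2 thus holds no exact place on the scale, and what is known is simply the limit of > 100000 nM in this assay, at which 2 of the 2 values shown sit, and nothing finer.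

Compound 3 `O=C(CCCCCCCCCc1ccccc1)N[C@H]1CCOC1=O` lengthens the chain again, and the change is benzyl in place of phenyl on a saturated chain carbon, eight bonds along the chain from a carbonyl carbon. Cut one bond further out, the same difference reads benzyl to phenethyl. Within the data shown here, the same kind of change, seven bonds along the chain, is a step that the two limits leave unreadable from compound 1 to compound 2 and it is the only measured step that bears on this one. With no readable size there, nothing points to a step beyond the scatter in either direction. The estimated change is a number no higher from compound 2 to compound 3 (the limit leaves the size open) and another bare limit is the likeliest report. Compound 3 is estimated at 100000 nM with an expected range from 40000 nM to 200000 nM on that scale.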

Compound 3, half-maximal inhibitory concentration: > 100000 nM
Compound 3: no number, only a limit (the forecaster's own chance of this, stated with the estimate: 80%); the middle value lies on the limit itself.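

No step can be read among compound 1, compound 2 and compound 3, because each result is a limit of the assay and not a number: the limit of > 100000 nM in this assay, at which 3 of the 3 values shown sit.

Left open is whether lengthening the chain changes the result in this assay at all, and where the true value of each compound lies beyond that limit.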